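Leaving cyclohexyl for a furan-bearing amide group

The source may report more compounds than this note shows. Statements on the series, on what has been measured and on what is new or still open speak of the compounds shown alone.

In a functional assay on MDA-MB-231 cells (Homo sapiens) for inhibition, read by MTT assay, with a stated time of 48 h (a higher number here means a weaker inhibitor, a lower number a stronger inhibitor), compound 3 `O=C(NC1CCCCC1)c1[nH]cnc1-c1nc2ccccc2[nH]1` gives 8300 nM, the lowest number in this small set. Compound 2 `O=C(NC1CC1)c1[nH]cnc1-c1nc2ccccc2[nH]1` gives 35200 nM. Compound 1 `CC(C)(C)NC(=O)c1[nH]cnc1-c1nc2ccccc2[nH]1` returns only a limit of the assay, > 40000 nM. Compound 4 `O=C(NCc1ccco1)c1[nH]cnc1-c1nc2ccccc2[nH]1` has (furan-2-yl)methyl in place of cyclohexyl on an amide-type nitrogen. The measured steps at this same nitrogen are a 4.2-fold lower number from compound 2 to compound 3 (0.63 log units; beyond the scatter) and an at least 4.8-fold lower number from compound 1 to compound 3 (0.68 log units; beyond the scatter), both beyond the scatter, whereas the floor of an at least 1.1-fold lower number from compound 1 to compound 2 (0.05 log units; that floor lies within the scatter) lies within it. In both larger steps cyclohexyl enters and the number falls, so losing cyclohexyl points to a higher number. The expected step is modest, a 2.4-fold higher number from compound 3 to compound 4 (0.38 log units; beyond the scatter). For compound 4 the estimate is 20000 nM, with an expected range of 8000 nM to 40000 nM.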

Compound 4, half-maximal inhibitory concentration: 22200 nM
Compound 4: the middle estimate sits 1.1-fold (0.05 log units) below what was measured, within the range that was stated.
By their numbers in this assay, from the lowest: compound 3; then compounds 4 and 2 (each within the scatter of the next). At a limit, above all of these: compound 1.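

Cyclohexyl and (furan-2-yl)methyl carry the same count of heavy atoms, yet the swap gives a 2.7-fold higher number from compound 3 to compound 4 (0.43 log units; beyond the scatter) and so this nitrogen answers to more than that count. From cyclopropyl, the change to (furan-2-yl)methyl gives a 1.6-fold lower number from compound 2 to compound 4 (0.20 log units; within the scatter) and leaves those two compounds unranked. From tert-butyl it gives an at least 1.8-fold lower number from compound 1 to compound 4 (0.25 log units; that floor lies within the scatter) as a mere floor, resting on a limit: the limit of > 40000 nM in this assay, at which 1 of the 4 values shown sits.

Still open, on these data alone, is whether benzyl, with a carbon-only aromatic ring on the same methylene link, would sit nearer compound 3 or compound 4. Cyclopentyl would show whether the cyclohexyl result holds for a smaller carbon ring.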